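Compound 3 to compound 4: one aromatic group swapped

This account rests on a few compounds, and the source may have more. Where it says the series, first, only, none or still open, it means among the compounds named here.

Three compounds have been measured so far in a functional assay on MCF7 cells (Homo sapiens) for inhibition, read by MTT assay, with a stated time of 72 h, tested at 50 uM; on this read-out lower numbers stand for less inhibition of growth and higher numbers for more inhibition of growth at the one concentration tested
compound 1 `C=CCc1ccc(OCc2cn(-c3cccc([N+](=O)[O-])c3)nn2)c(O)c1` gives 56.5%
compound 2 `C=CCc1ccc(OCc2cn(-c3ccc(C#N)cc3)nn2)c(O)c1` gives 35.6%
compound 3 `C=CCc1ccc(OCc2cn(-c3ccccc3CO)nn2)c(O)c1` gives 40.4%

Compound 3 cannot be told apart from compound 2 on these numbers, since the two lie within the scatter of each other. Compound 1 stands clearly higher than both. The next compound to be tested, compound 4 `C=CCc1ccc(OCc2cn(-c3cccc(C#N)c3)nn2)c(O)c1`, keeps the shared core and changes one group, with 3-cyanophenyl in place of 2-(hydroxymethyl)phenyl on an aromatic nitrogen. The change counts out as 3-cyanophenyl in place of 2-(hydroxymethyl)phenyl on an aromatic nitrogen and removes the hydrogen-bond donor of the leaving group.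

Going by the values given here, one measured step bears directly on this swap. It is a number 4.8 percentage points higher from compound 2 to compound 3 (within the scatter) and it put 2-(hydroxymethyl)phenyl in place of 4-cyanophenyl, a group with the same nitrile as the one now entering. That step stayed small, so no step beyond the scatter is expected in this assay for the new swap. Compound 1 at 56.5% carries a nitro group instead of a nitrile, and this leaves some room upward in the range. The expected size is a number 1.6 percentage points higher from compound 3 to compound 4 (within the scatter) in this estimate. For compound 4 the estimated value is 42% with an expected range from 30% to 56% in this assay's terms.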

Compound 4, percent growth inhibition at one concentration: 33.4%
Estimate against measurement, compound 4: 8.6 percentage points above; the measured number falls inside the stated range.
By their numbers in this assay, from the lowest: compounds 4, 2 and 3 (each within the scatter of the next); then compound 1.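

Changing 3-cyanophenyl for 4-cyanophenyl on the aromatic nitrogen gives a number 2.2 percentage points lower from compound 2 to compound 4 (within the scatter) in this assay, so these two nitrile-bearing groups cannot be told apart at this one concentration. The swap of 2-(hydroxymethyl)phenyl for 3-cyanophenyl gives a number 7 percentage points lower from compound 3 to compound 4 (within the scatter), which means that the loss of the hydrogen-bond donor of the leaving group comes with no change that can be read, even though the attached group also differs in its substituent and where that substituent sits. The clear contrast comes from a single exchange on an aromatic carbon, cyano in place of nitro, which gives a number 23.1 percentage points lower from compound 1 to compound 4 (beyond the scatter) and shows that this assay can separate compounds that differ only in that one small group.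

The compounds shown offer no measurement that explains why nitro and cyano part here. On these data alone, it also remains open where an amine, a carboxylic acid or a methoxy group on that same aromatic carbon would fall, whether with the nitro compound or with the nitrile compounds.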